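Two fluorines on the anilide: lipophilicity at the limit

The compounds below may be only part of what the source reports. "The series", "measured", "known", "first", "only" and "open" are said of these compounds alone.

compound 1 `Cc1cc(C(=O)O)nn1C(C)c1cc(Cl)ccc1OCc1ccccc1`: 1
compound 2 `Cc1cc(C(=O)Nc2ccccc2)nn1Cc1cc(Cl)ccc1OCc1ccccc1`: > 3.7

In a physicochemical assay for lipophilicity, at pH 7.4 (on this read-out higher numbers stand for higher lipophilicity and lower numbers for lower lipophilicity), compound 1 gives 1. For compound 2 the reading > 3.7 is a limit of the assay, not a number. Going by the values given here, compound 2 therefore stands at the upper edge of this assay, as the limit of > 3.7 in this assay, at which 1 of the 2 values shown sits, shows, so no step between the two measured compounds can be sized. Compound 3 `Cc1cc(C(=O)Nc2c(F)cccc2F)nn1Cc1cc(Cl)ccc1OCc1ccccc1` carries 2,6-difluorophenyl in place of phenyl on an amide-type nitrogen. Compound 3 is expected to move by a step that the limit leaves unreadable from compound 2 to compound 3 in this assay, a small rise. Compound 3 is estimated at 4.2, between 3.8 and 4.8, and will most likely again be reported only as a limit.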

Compound 3, distribution coefficient: 3.7
The estimate for compound 3 lay 0.50 log units above the measured number; the measured number lies below the stated range.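

In this assay compound 3 gives 3.7 as a real number, so with 2,6-difluorophenyl in place of phenyl on an amide-type nitrogen this position yields a measured reading. Compound 2 carries > 3.7 as a limit of the assay and not a number. The change reads as a number no higher from compound 2 to compound 3 (the limit leaves the size open) and no size can be given, because compound 2 stands at the limit: the limit of > 3.7 in this assay, at which 1 of the 3 values shown sits.

Going by these compounds, whether a carboxylic acid or an amine on that phenyl would give a lower reading stays open, as does how a single fluorine compares with the two in compound 3.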